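The compounds below may be only part of what the source reports. "The series", "measured", "known", "first", "only" and "open" are said of these compounds alone.

Compound 1 (`COc1cccc(NC(=O)[C@H]2CN(C)C[C@@H]2c2ccc(/C=C/C(=O)Nc3ccccc3N)cc2)c1`) and compound 2 (`CN1C[C@H](C(=O)Nc2ccccn2)[C@@H](c2ccc(/C=C/C(=O)Nc3ccccc3N)cc2)C1`) share one core and differ in a single group. In an in vitro ADME assay on microsomes from liver (Mus musculus) for pharmacokinetics, read by LC-MS, with a stated time of 10 min, tested at 1 uM (on this read-out lower numbers stand for slow clearance and higher numbers for fast clearance), compound 1 gives 65 mL/min/kg and compound 2 gives 40 mL/min/kg on the same scale. These two numbers lie within the usual scatter of each other, so compound 2 cannot be told apart from compound 1 on this measurement.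

Compound 3 (`CC(C)NC(=O)[C@H]1CN(C)C[C@@H]1c1ccc(/C=C/C(=O)Nc2ccccc2N)cc1`) is changed at the same amide-type nitrogen (isopropyl in place of pyridin-2-yl on an amide-type nitrogen), with isopropyl in place of pyridin-2-yl. Within the data shown here, only one measured step touches this nitrogen, namely a 1.6-fold lower number from compound 1 to compound 2 (0.21 log units; within the scatter) and it stayed within the scatter. That step exchanged one aromatic ring for another, while compound 3 carries no ring there, so it is only a weak guide. No step beyond the scatter is therefore expected in this assay in either direction. The estimated step is a 1.1-fold higher number from compound 2 to compound 3 (0.05 log units; within the scatter) and it is small. For compound 3 the expected clearance is 45 mL/min/kg with a range from 22 mL/min/kg to 90 mL/min/kg in repeat measurements.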

Compound 3, clearance: 12 mL/min/kg
For compound 3 the middle estimate is 3.8-fold (0.57 log units) above the measured one; measured number below the stated range.
By their numbers in this assay, from the lowest: compound 3; then compounds 2 and 1 (each within the scatter of the next).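

In this assay, isopropyl on the amide-type nitrogen gives a 3.3-fold lower number from compound 2 to compound 3 (0.52 log units; beyond the scatter) when it replaces pyridin-2-yl, and a 5.4-fold lower number from compound 1 to compound 3 (0.73 log units; beyond the scatter) when it replaces 3-methoxyphenyl. Among these compounds, the only earlier step at this nitrogen, a 1.6-fold lower number from compound 1 to compound 2 (0.21 log units; within the scatter) from one aromatic ring to another, left open whether this position could move clearance at all, and these new steps show that it can, with the compound lacking a ring there lying clearly lower than both compounds that carry one. No evidence is available on why the clearance falls with this exchange.

With isopropyl as the only group without a ring, the compounds shown cannot separate the effect of losing the aromatic ring from something specific to isopropyl itself. A longer chain such as n-butyl, a saturated ring such as cyclohexyl, or a chain ending in an amine on the same nitrogen would show whether the lower clearance extends to other groups without an aromatic ring or belongs to isopropyl alone.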